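This account rests on a few compounds, and the source may have more. Where it says the series, first, only, none or still open, it means among the compounds named here.

Compound 1 `O=C(COc1cccc2ccccc12)N/N=C/c1ccccc1Br`: 4.81
Compound 2 `O=C(COc1cccc2ccccc12)N/N=C/c1ccccc1O`: 3.73
Compound 3 `O=C(COc1cccc2ccccc12)N/N=C/c1ccccc1Cl`: 4.54

In a physicochemical assay for lipophilicity, measured as octanol-water partition (on this read-out lower numbers stand for lower lipophilicity and higher numbers for higher lipophilicity), compound 3 stands second highest of the three numbers; the nearest number comes with a number 0.27 log units lower from compound 1 to compound 3 (within the scatter), within the scatter, and the furthest with a number 0.81 log units higher from compound 2 to compound 3 (beyond the scatter), beyond it. Compound 4 `O=C(COc1cccc2ccccc12)N/N=C/c1ccccc1[N+](=O)[O-]` differs from compound 3 by nitro in place of chloro on an aromatic carbon. For the measured compounds named here, no measured step exchanges chloro for nitro. Going by the values given here, the halogen swap a number 0.27 log units lower from compound 1 to compound 3 (within the scatter) stayed within the scatter, whereas the one step in which chloro replaced a group carrying a heteroatom, a number 0.81 log units higher from compound 2 to compound 3 (beyond the scatter), was modest. Moving from chloro to a group counted with two hydrogen-bond acceptors is therefore expected to lower this assay by a modest step, a number 0.74 log units lower from compound 3 to compound 4 (beyond the scatter). Compound 4 is estimated at 3.8, with a range of 3.3 to 4.3.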

Compound 4, partition coefficient: 3.97
Compound 4: middle estimate off by 0.17 log units, on the low side; the range from low to high includes it.
By their numbers in this assay, from the lowest: compounds 2 and 4 (each within the scatter of the next); then compounds 3 and 1 (each within the scatter of the next).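

In this assay, nitro at this position gives a number 0.57 log units lower from compound 3 to compound 4 (beyond the scatter) and a number 0.84 log units lower from compound 1 to compound 4 (beyond the scatter), so a replacement for a halogen other than hydroxy also produces a step beyond the scatter. Nitro also lands close to hydroxy, with a number 0.24 log units higher from compound 2 to compound 4 (within the scatter); across these four compounds, the two halogens form one pair and hydroxy and nitro the other, with no compound against this split. Nothing available explains the split. Open, going by these compounds, is where an amine, a carboxylic acid or a methoxy group would fall at this position, and whether the split holds elsewhere on the ring.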